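The compounds below may be only part of what the source reports. "The series", "measured", "known", "first", "only" and "open" are said of these compounds alone.

Measured compounds in a functional assay on MM1 cells (Homo sapiens) for antiproliferative activity, read by MTT assay, with a stated time of 72 h; on this read-out higher numbers stand for weaker inhibition and lower numbers for stronger inhibition:
compound 1 `CCC[C@H](NC(=O)/C(C#N)=C/c1ccc(O)c(Br)c1)c1ccccc1`: > 10000 nM
compound 2 `N#C/C(=C\c1ccc(Cl)c([N+](=O)[O-])c1)C(=O)N[C@@H](CO)c1ccccc1`: > 10000 nM
compound 3 `N#C/C(=C\c1ccc(-c2cccc([N+](=O)[O-])c2)o1)C(=O)NC(c1ccccc1)C1CC1`: > 10000 nM

Each of these three values is a limit of this assay rather than a number. Compound 3 therefore stands at the limit, and so do compound 1 and compound 2, so no order among them can be read from the numbers. Compound 4 `N#C/C(=C\c1ccc(-c2cccc([N+](=O)[O-])c2)o1)C(=O)NCc1ccccc1Cl` differs from compound 3 in one place: 2-chlorobenzyl in place of cyclopropyl(phenyl)methyl on an amide-type nitrogen. Within the data shown here, no step between measured compounds is available to size this change, and because the limit of > 10000 nM in this assay, at which 3 of the 3 values shown sit, gives no numbers to compare, no direction can be drawn from the data. The expected step that the limit leaves unreadable from compound 3 to compound 4 is estimated as none beyond the scatter, with compound 4 most likely reported as a limit again. Compound 4 is expected to give 15000 nM, within a range of 4000 nM to 60000 nM.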

Compound 4, half-maximal inhibitory concentration: > 10000 nM
Compound 4 was reported as a limit; the forecaster's own chance of this, stated with the estimate: 75%; the middle value is on the limit's open side.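

Among these compounds, no step from compound 3 to compound 4 can be read in this assay because both values are limits: the limit of > 10000 nM in this assay, at which 4 of the 4 values shown sit.

The compounds shown leave open how 2-chlorobenzyl and cyclopropyl(phenyl)methyl compare on the amide-type nitrogen, and whether any of these compounds has a measurable potency.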